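The source may hold more compounds than are shown below. What is called first, only, known or untested is meant among the compounds shown, and "the series" means these compounds.

Compound 3, `CC1CCN(c2c(S(=O)(=O)c3ccc(Cl)cc3)cnc3ccc(Cl)cc23)CC1`, stands highest of the three compounds measured in an assay on isolated protein for displacement of a labelled ligand from metabotropic glutamate receptor 5 (Homo sapiens), with a stated time of 60 min, tested at 1 uM (on this read-out higher numbers stand for more inhibition at the one concentration tested (going by the name of the read-out) and lower numbers for less inhibition), and compound 3 gives 92%. The nearest of the other two is compound 2, `Cc1ccc2ncc(S(=O)(=O)c3ccc(F)cc3)c(N3CCC(C)CC3)c2c1`, which gives 90%, a gap that lies within the scatter. The furthest is compound 1, `CC1CCN(c2c(S(=O)(=O)c3cccc(F)c3)cnc3ccc(Cl)cc23)CC1`, which gives 58%. For the measured compounds named here, the one step measured between compounds that differ in a single place is a number 34 percentage points higher from compound 1 to compound 3 (beyond the scatter), and it is the only measured step that bears on the next change at all.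

Compound 4, `CC1CCN(c2c(S(=O)(=O)c3ccc(F)cc3)cnc3ccc(Cl)cc23)CC1`, differs from compound 3 by fluoro in place of chloro on an aromatic carbon. That measured step does not isolate this change, since it moves the halogen to another carbon as well as exchanging it. Compound 2, which carries the 4-fluorophenyl on the sulfonyl sulfur on a different core, sits close to compound 3, so a halogen exchange at this carbon is not expected to move the read-out much. Compound 4 is therefore expected to stay near compound 3, with a number 7 percentage points lower from compound 3 to compound 4 (within the scatter) within the scatter. The estimate for compound 4 is 85%, between 70% and 96%.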

Compound 4, a percentage reported as inhibition, at one concentration (the size of the read-out at that concentration, not a potency): 89%
For compound 4 the middle estimate is 4 percentage points below the measured one; measured number inside the range.
By their numbers in this assay, from the lowest: compound 1; then compounds 4, 2 and 3 (each within the scatter of the next).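

In this assay fluoro in place of chloro on this aromatic carbon, para to a large group, gives a number 3 percentage points lower from compound 3 to compound 4 (within the scatter) and so isolates the exchange that the earlier step had mixed with a move of the halogen. The same comparison with the halogen held as fluoro, 4-fluorophenyl in place of 3-fluorophenyl on the sulfonyl sulfur, gives a number 31 percentage points higher from compound 1 to compound 4 (beyond the scatter) and ties the large step to the place of the halogen on that ring. On the core, chloro in place of methyl gives a number 1 percentage points lower from compound 2 to compound 4 (within the scatter) with the 4-fluorophenyl kept.

Open, going by these compounds, is whether this carbon accepts anything other than a halogen, such as a methoxy group, a nitrile or an amine, and how 3-chlorophenyl would read on the sulfonyl sulfur. Nothing shown here gives a reason for these steps.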